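Aryl swap at the alkyne terminus: expectation for compound 3

This account rests on a few compounds, and the source may have more. Where it says the series, first, only, none or still open, it means among the compounds named here.

Growth inhibition in a functional assay on K562 cells (Homo sapiens) for cytotoxicity; a higher number here means a weaker inhibitor of growth, a lower number a stronger inhibitor of growth:
compound 1 `OCCCCC#Cc1ccccc1C#Cc1ccccc1` — 21100 nM
compound 2 `OCCCCC#Cc1ccccc1C#Cc1ccccn1` — 29000 nM

Compound 2 and compound 1 lie within the scatter of each other, as a 1.4-fold higher number from compound 1 to compound 2 (0.14 log units; within the scatter) shows; the two numbers cannot be ranked. Compound 3 `OCCCCC#Cc1ccccc1C#Cc1cccs1` differs from compound 2 by thiophen-2-yl in place of pyridin-2-yl on a triple-bonded carbon. Within the data shown here, the only step measured, a 1.4-fold higher number from compound 1 to compound 2 (0.14 log units; within the scatter), is an exchange of the aryl group at this same position and stayed within the scatter. Because a 1.4-fold higher number from compound 1 to compound 2 (0.14 log units; within the scatter) was within the scatter, the expected step is estimated as a 1.1-fold lower number from compound 2 to compound 3 (0.05 log units; within the scatter), with no shift beyond the scatter. Compound 3 is therefore estimated at 26000 nM, between 11000 nM and 60000 nM.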

Compound 3, concentration for 50% growth inhibition: 20300 nM
Compound 3: middle estimate off by 1.3-fold (0.11 log units), on the high side, within the range that was stated.
By their numbers in this assay, from the lowest: compounds 3, 1 and 2 (each within the scatter of the next).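

In this assay thiophen-2-yl gives a 1.4-fold lower number from compound 2 to compound 3 (0.15 log units; within the scatter) and also a 1.0-fold lower number from compound 1 to compound 3 (0.02 log units; within the scatter), so a five-membered aromatic ring on this triple-bonded carbon cannot be told apart from either six-membered aromatic ring. The three aryl groups at this position therefore cannot be ranked. No measurement is available that would explain this result.

Still open, going by these compounds, is whether any change moves the number beyond the scatter, such as an amine or a carboxylic acid on the aryl group, or a longer chain in place of the one carrying the alcohol.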